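The compounds below may be only part of what the source reports. "The series", "measured", "known", "first", "only" and "open" are said of these compounds alone.

Measured in an ADME assay on HUVEC cells (Homo sapiens) for cytotoxicity, read by MTT assay, with a stated time of 24 h; on this read-out higher numbers stand for lower toxicity in this test and lower numbers for higher toxicity in this test:
- compound 1 `O=[N+]([O-])c1ccccc1/C=C/c1nnc(-c2ccc3c(c2)OCCO3)o1`: 323000 nM
- compound 2 `Clc1ccccc1/C=C/c1nnc(-c2ccc3c(c2)OCCO3)o1`: 368000 nM
- compound 3 `Fc1cccc(/C=C/c2nnc(-c3ccc4c(c3)OCCO4)o2)c1`: 295000 nM

Compound 2 stands at 368000 nM, level with both of the other measured compounds. The two steps that touch it, a 1.1-fold higher number from compound 1 to compound 2 (0.06 log units; within the scatter) and a 1.2-fold lower number from compound 2 to compound 3 (0.10 log units; within the scatter), are both within the scatter.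

Compound 4 `COc1cccc(/C=C/c2nnc(-c3ccc4c(c3)OCCO4)o2)c1` has not yet been measured. Its difference from compound 2 is 3-methoxyphenyl in place of 2-chlorophenyl on a double-bonded chain carbon bound to a double-bonded chain carbon.

Among the measured compounds shown here, the closest precedent replaces the same 2-chlorophenyl at the same place with 3-fluorophenyl, and that step is a 1.2-fold lower number from compound 2 to compound 3 (0.10 log units; within the scatter). The swap of nitro for chloro on an aromatic carbon, a 1.1-fold higher number from compound 1 to compound 2 (0.06 log units; within the scatter), bears on the change less directly. For the measured compounds named here, neither step leaves the scatter, although the base is only these compounds and no compound carrying 3-methoxyphenyl has a measured value.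

As far as these compounds go, no step beyond the scatter is therefore expected in this assay, and the direction stays open. The estimated step is a 1.2-fold lower number from compound 2 to compound 4 (0.06 log units; within the scatter). The estimate for compound 4 is 320000 nM, with an expected range from 190000 nM to 530000 nM.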

Compound 4, half-maximal cytotoxic concentration: 332000 nM
For compound 4 the middle estimate is 1.0-fold (0.02 log units) below the measured one; low and high end bracket the measured number.
By their numbers in this assay, from the lowest: compounds 3, 1, 4 and 2 (each within the scatter of the next).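

In this assay, 3-methoxyphenyl in place of 2-chlorophenyl on a double-bonded chain carbon bound to a double-bonded chain carbon gives a 1.1-fold lower number from compound 2 to compound 4 (0.04 log units; within the scatter) and so stays within the scatter, which shows that this place tolerates a group with one hydrogen-bond acceptor and one more heavy atom than 2-chlorophenyl without a measurable shift in this test. Methoxy in place of fluoro on an aromatic carbon gives a 1.1-fold higher number from compound 3 to compound 4 (0.05 log units; within the scatter) and adds a direct comparison of two groups on the same phenyl carbon, with no separation between them in this assay either. The data offer nothing that explains why these changes leave the read-out within the scatter.

The compounds shown leave open whether any change at this place can produce a step beyond the scatter, for example a primary amine or a carboxylic acid on the phenyl ring, or a longer alkoxy chain in place of methoxy. They also leave open whether a saturated ring or a pyridine in place of the phenyl ring would keep the number within the scatter of compound 4.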